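Fluoro step from a compound at the assay limit

The source may hold more compounds than are shown below. What is called first, only, known or untested is meant among the compounds shown, and "the series" means these compounds.

In an ADME assay on T29 cells (Homo sapiens) for cytotoxicity, read by sulforhodamine B assay, with a stated time of 3 days (on this read-out higher numbers stand for weaker inhibition and lower numbers for stronger inhibition), compound 1 `O=Cc1cn(Cc2ccc(Cl)cc2)c2ccc(F)cc12` gives > 31600 nM, which is a limit and not a number. Compound 2 `OCc1cn(Cc2ccc(Cl)cc2)c2ccccc12` gives > 31600 nM, also a limit, so it stands without a number. Both compounds sit at the same point: the limit of > 31600 nM in this assay, at which 2 of the 2 values shown sit. Compound 3 `OCc1cn(Cc2ccc(Cl)cc2)c2ccc(F)cc12` has fluoro in place of hydrogen on an aromatic carbon of compound 2 (fluoro in place of hydrogen on an aromatic carbon). Among the compounds with values here, no measured step gauges this change. The expected change in this assay is none beyond the scatter, with an estimated step that the limit leaves unreadable from compound 2 to compound 3. A further limit is the likeliest report. For compound 3 the estimated value is 35000 nM, with an expected range of 18000 nM to 70000 nM.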

Compound 3, half-maximal inhibitory concentration: 8120 nM
Estimate against measurement, compound 3: 4.3-fold (0.63 log units) above; measured number below the stated range.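

With hydroxymethyl held, fluoro in place of hydrogen on this aromatic carbon gives an at least 3.8-fold lower number from compound 2 to compound 3 (0.59 log units; beyond the scatter) in this assay. With fluoro held, hydroxymethyl in place of formyl gives an at least 3.8-fold lower number from compound 1 to compound 3 (0.59 log units; beyond the scatter), so a measurable number appears only where fluoro and hydroxymethyl occur together. Both sizes remain lower bounds, and the full size of neither step can be read: the limit of > 31600 nM in this assay, at which 2 of the 3 values shown sit.

Still open, on these data alone, is whether chloro or methoxy on the same aromatic carbon would shift the number as fluoro does. Also open, as far as these compounds go, is whether an amine or a carboxylic acid in place of hydroxymethyl would keep it.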